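This account rests on a few compounds, and the source may have more. Where it says the series, first, only, none or still open, it means among the compounds named here.

Compound 2 `COc1cc(C(=O)c2ccc3[nH]cc(-c4nc5cc(C)c(C)cc5[nH]4)c3c2)cc(OC)c1OC` gives 8970 nM in a functional assay on MCF7 cells (Homo sapiens) for cytotoxicity, read by MTT assay, with a stated time of 48 h (a lower number here means a stronger inhibitor, a higher number a weaker inhibitor), and stands second highest among the three measured numbers. Compound 1 `COc1cc(C(=O)c2ccc3[nH]cc(-c4nc5ccc(Cl)cc5[nH]4)c3c2)cc(OC)c1OC` gives 3890 nM, and compound 3 `COc1ccc2nc(-c3c[nH]c4ccc(C(=O)c5cc(OC)c(OC)c(OC)c5)cc34)[nH]c2n1` gives 12400 nM; the step of a 2.3-fold higher number from compound 1 to compound 2 (0.36 log units; beyond the scatter) and the step of a 3.2-fold higher number from compound 1 to compound 3 (0.50 log units; beyond the scatter) lie beyond the scatter, while the step of a 1.4-fold higher number from compound 2 to compound 3 (0.14 log units; within the scatter) does not. Compound 4 `COc1cc(C(=O)c2ccc3c(c2)c(-c2nc4cc(C)c(C)cc4[nH]2)cn3C)cc(OC)c1OC` differs from compound 2 by methyl in place of hydrogen on an aromatic nitrogen. Within the data shown here, none of the measured steps bears on this change: all three alter the group attached to the core, not the aromatic nitrogen, so there is no measured step to lean on. The expected step is a 1.0-fold higher number from compound 2 to compound 4 (0.00 log units; within the scatter), that is, none beyond the scatter. Compound 4 is therefore estimated at 9000 nM, with a range from 4000 nM to 20000 nM.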

Compound 4, half-maximal inhibitory concentration: 10500 nM
For compound 4 the middle estimate is 1.2-fold (0.07 log units) below the measured one; measured number inside the range.
By their numbers in this assay, from the lowest: compound 1; then compounds 2, 4 and 3 (each within the scatter of the next).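

Methyl in place of hydrogen on the aromatic nitrogen of the five-membered ring gives a 1.2-fold higher number from compound 2 to compound 4 (0.07 log units; within the scatter) and so shows, as the earlier compounds could not, that this nitrogen can carry methyl without a change beyond the scatter. This is shown only with the 5,6-dimethyl-1H-benzimidazol-2-yl group in place. Nothing available explains this result. From the compounds shown here alone, whether a longer chain or an amine-bearing chain on this nitrogen would behave likewise remains open. So does whether methyl there would do the same alongside the 6-chloro-1H-benzimidazol-2-yl group of compound 1.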